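Swapping Hydroxymethyl for Carboxy on a Weak Antiproliferative Amide

The source may report more compounds than this note shows. Statements on the series, on what has been measured and on what is new or still open speak of the compounds shown alone.

Compound 1 `CCn1c(C(=O)N[C@@H](C)CO)ccc1C(CC)(CC)c1ccc(OCS(=O)(=O)c2ccccc2)c(C)c1` is a weak inhibitor in a functional assay on PC-3 cells (Homo sapiens) for antiproliferative activity, read by MTT assay, with a stated time of 24 h (a higher number here means a weaker inhibitor, a lower number a stronger inhibitor), where compound 1 gives 9520 nM. Among the measured compounds shown here, of the two numbers measured so far it is the lower one, and the only neighbour is compound 2 `CCn1c(C(=O)NCCO)ccc1C(CC)(CC)c1ccc(OCS(=O)(=O)c2ccccc2)c(C)c1`, which in this assay gives 17700 nM. For the measured compounds named here, the single measured step, a 1.9-fold higher number from compound 1 to compound 2 (0.27 log units; within the scatter), puts hydrogen in place of methyl on a saturated chain carbon bound to an amide-type nitrogen and a saturated chain carbon, and stays within the scatter. Compound 3 `CCn1c(C(=O)N[C@@H](C)C(=O)O)ccc1C(CC)(CC)c1ccc(OCS(=O)(=O)c2ccccc2)c(C)c1` differs from compound 1 at the same part of the molecule: carboxy in place of hydroxymethyl on a saturated chain carbon bound to an amide-type nitrogen and a saturated chain carbon. Going by the values given here, no measured step touches a hydroxymethyl or a carboxy group, so the only guidance is that the one change recorded so far in this chain left the number within the scatter. On that thin basis the step is expected to be small, a 1.3-fold higher number from compound 1 to compound 3 (0.10 log units; within the scatter), with no clear direction beyond the scatter. Compound 3 is therefore estimated at 12000 nM in this assay, within a range from 4000 nM to 40000 nM.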

Compound 3, half-maximal inhibitory concentration: 16800 nM
Compound 3: middle estimate off by 1.4-fold (0.15 log units), on the low side, and the stated range covers the measured number.
By their numbers in this assay, from the lowest: compounds 1, 3 and 2 (each within the scatter of the next).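

In this assay, putting carboxy in place of hydroxymethyl gives a 1.8-fold higher number from compound 1 to compound 3 (0.25 log units; within the scatter) and so stays within the scatter, which extends what was seen for the loss of a methyl to a quite different kind of group on the same saturated chain carbon. Exchanging the whole side chain, with 1-carboxyethyl in place of 2-hydroxyethyl on an amide-type nitrogen, gives a 1.1-fold lower number from compound 2 to compound 3 (0.02 log units; within the scatter) and is also within the scatter. Together with the earlier step, this means that the three compounds cannot be told apart here, so none of the groups shown at this position stands out from the others, and no measurement is available to explain why the numbers lie so close together.

Still open, going by these compounds, is what a different group at this place would do: an amine, a methyl ester or a longer chain on the saturated chain carbon bound to the amide-type nitrogen might or might not leave the number where it is. The compounds shown also leave open whether any change at this position, on the shared core, can move the number beyond the scatter at all.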